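Swapping the Amide Partner: Cytotoxicity Outlook

The compounds below may be only part of what the source reports. "The series", "measured", "known", "first", "only" and "open" are said of these compounds alone.

Among the measured compounds shown here, compound 1 `CC(C)n1ncc2c(C(=O)N3CCc4cccnc43)cc(-c3cccs3)nc21` is the only compound here with a numeric value: in an ADME assay on LLC-MK2 cells (Macaca mulatta) for cytotoxicity, read by spectrophotometry and crystal violet staining, with a stated time of 4 days (a lower number here means that less compound is tolerated, a higher number that more compound is tolerated), compound 1 gives 50000 nM. Compound 2 `CC(C)n1ncc2c(C(=O)Nc3cccc(S(=O)(=O)N(C)C)c3)cc(-c3cccs3)nc21` is reported only as a limit of the assay, > 200000 nM. Compound 3 `CC(C)n1ncc2c(C(=O)Nc3ccncn3)cc(-c3cccs3)nc21` has not been measured. It differs from compound 1 at the carbonyl carbon: a group of 7 heavy atoms (4 carbon, 3 nitrogen; one six-membered aromatic ring with 2 hetero atoms) in place of a group of 9 heavy atoms (7 carbon, 2 nitrogen; one five-membered non-aromatic ring with 1 hetero atom, one six-membered aromatic ring with 1 hetero atom), on a carbonyl carbon. For the measured compounds named here, no step between measured compounds is available, so the size of this change cannot be read off directly. The change is expected to give a modest step toward a higher value, a 1.8-fold higher number from compound 1 to compound 3 (0.26 log units; within the scatter), not clearly beyond the usual scatter. Compound 3 is therefore estimated at 90000 nM, with a range from 30000 nM to 200000 nM.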

Compound 3, half-maximal cytotoxic concentration: 50000 nM
Compound 3: middle estimate off by 1.8-fold (0.26 log units), on the high side; the measured number falls inside the stated range.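

In this assay there is no change at the digits printed from compound 1 to compound 3 (within the scatter) when (pyrimidin-4-yl)amino takes the place of the group on the carbonyl carbon. Among the compounds shown here, this gives the first direct step at this position: going from two rings to one, with a hydrogen-bond donor entering, does not move the number beyond the scatter. Nothing measured here accounts for this outcome.

Still open, from the compounds shown here alone, is how a simple alkyl amine or a carboxylic acid on the carbonyl carbon would read in this assay. Also open, going by these compounds, is whether any partner at this position gives a step beyond the scatter.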